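Truncating the piperazine tail of compound 1

This account rests on a few compounds, and the source may have more. Where it says the series, first, only, none or still open, it means among the compounds named here.

Measured so far, in a functional assay on SK-BR-3 cells (Homo sapiens) for antiproliferative activity, read by MTT assay, with a stated time of 72 h; on this read-out higher numbers stand for weaker inhibition and lower numbers for stronger inhibition:
compound 1, `Cc1cc(NCCN2CCN(C)CC2)nc2ccc(NC(=O)c3ccc(Cl)c(Cl)c3)cc12`: 2690 nM
compound 2, `CCc1ccc(C(=O)Nc2ccc3nc(N4CCN(CC)CC4)cc(C)c3c2)cc1`: 9850 nM
compound 3, `CCN1CCN(c2cc(C)c3cc(NC(=O)c4ccc(F)cc4)ccc3n2)CC1`: 19800 nM

Compound 1 gives the lowest number of the three in this assay; compound 2 and compound 3 lie higher, both beyond the scatter. Among the compounds with values here, the one single-point step among the measured compounds is a 2.0-fold higher number from compound 2 to compound 3 (0.30 log units; within the scatter), which touches the amide side of the shared core and not the aminoquinoline side.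

Compound 4, `CNc1cc(C)c2cc(NC(=O)c3ccc(Cl)c(Cl)c3)ccc2n1`, is compound 1 with hydrogen in place of (4-methylpiperazin-1-yl)methyl on a saturated chain carbon bound to a nitrogen on an aromatic ring. Within the data shown here, no measured step bears on this change: the only recorded step concerns a different position and is within the scatter. Compound 2 and compound 3 keep a ring on the nitrogen of the core and give higher numbers than compound 1, but they differ from it at the amide as well, so they show nothing clean about the tail. The expectation for compound 4 is therefore loose and leans toward a higher number, with a 2.2-fold higher number from compound 1 to compound 4 (0.35 log units; beyond the scatter). Compound 4 is estimated at 6000 nM, in the range 2000 nM to 20000 nM.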

Compound 4, half-maximal inhibitory concentration: 6350 nM
Compound 4: middle estimate off by 1.1-fold (0.02 log units), on the low side; the measured number falls inside the stated range.
By their numbers in this assay, from the lowest: compound 1; then compounds 4, 2 and 3 (each within the scatter of the next, the first and the last beyond it).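

In this assay the tail is now isolated from the amide side: going from (2-(4-methylpiperazin-1-yl)ethyl)amino to methylamino gives a 2.4-fold higher number from compound 1 to compound 4 (0.37 log units; beyond the scatter) and the rest of the molecule stays the same. Within the data shown here, this is the first clean read on this position, and it points the same way as the opening lead, with the full tail on the lower side. The step is modest, so the number stays measurable with the whole (4-methylpiperazin-1-yl)methyl portion gone. Nothing measured here bears on the reason for this step.

Open, as far as these compounds go, is whether a part of the tail suffices: a 2-(dimethylamino)ethyl chain, a 2-hydroxyethyl chain or a plain amino group at this nitrogen would place the number relative to compound 1 and compound 4. Also open, from the compounds shown here alone, is whether the same tail change reads alike with an ethyl or fluoro group on the amide side.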